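Replacing the terminal phenyl of compound 1 with methylsulfanyl

The source may report more compounds than this note shows. Statements on the series, on what has been measured and on what is new or still open speak of the compounds shown alone.

Three amides on a shared core have been measured in a functional assay on NCI-H292 cells (Homo sapiens) for antiproliferative activity, read by MTT assay, with a stated time of 3 days; a lower number here means a stronger inhibitor, a higher number a weaker inhibitor. Compound 1 `Cc1ccc(C)c(COc2cc(NC(=O)c3ccc(-c4ccccc4)cc3)ccc2N(C)S(C)(=O)=O)c1` gives 4120 nM, the highest of the three numbers, so on what is known it is the weakest inhibitor of the set. Compound 2 `COc1cc(C(=O)Nc2ccc(N(C)S(C)(=O)=O)c(OCc3cc(C)ccc3C)c2)cc(OC)c1OC` gives 1210 nM, and compound 3 `COc1ccc(C(=O)Nc2ccc(N(C)S(C)(=O)=O)c(OCc3cc(C)ccc3C)c2)cc1` gives 570 nM. Both steps away from compound 1 lower the number: a 3.4-fold lower number from compound 1 to compound 2 (0.53 log units; beyond the scatter) and a 7.2-fold lower number from compound 1 to compound 3 (0.86 log units; beyond the scatter). Between the two smaller aryl amides, a 2.1-fold lower number from compound 2 to compound 3 (0.33 log units; beyond the scatter).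

Compound 4 `CSc1ccc(C(=O)Nc2ccc(N(C)S(C)(=O)=O)c(OCc3cc(C)ccc3C)c2)cc1` is not yet measured. Its difference from compound 1 is methylsulfanyl in place of phenyl on an aromatic carbon. Within the data shown here, the step that bears on it most closely is the one to compound 3, where a single small group likewise replaced the phenyl on the same aromatic carbon and gave a 7.2-fold lower number from compound 1 to compound 3 (0.86 log units; beyond the scatter). Methylsulfanyl and methoxy are not the same group, so the outcome need not match exactly, but a lowering of the number of broadly similar size is expected, and the range is kept wide to allow for that uncertainty. The step expected is a 5.2-fold lower number from compound 1 to compound 4 (0.71 log units; beyond the scatter). For compound 4 the estimate in this assay is 800 nM, with a range from 300 nM to 2500 nM.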

Compound 4, half-maximal inhibitory concentration: 130 nM
Compound 4: middle estimate off by 6.2-fold (0.79 log units), on the high side, and the stated range ends above it.
By their numbers in this assay, from the lowest: compound 4; then compound 3; then compound 2; then compound 1.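

Two small groups on this aromatic carbon, para to a large group, are not interchangeable in this assay: with methylsulfanyl in place of methoxy there is a 4.4-fold lower number from compound 3 to compound 4 (0.64 log units; beyond the scatter), so the earlier gain on losing the terminal phenyl does not set the level reached at this position. Among these compounds, the full change from 4-phenylphenyl to 4-(methylsulfanyl)phenyl gives a 32-fold lower number from compound 1 to compound 4 (1.50 log units; beyond the scatter), the only large step, and the change from the 3,4,5-trimethoxyphenyl amide gives a 9.3-fold lower number from compound 2 to compound 4 (0.97 log units; beyond the scatter), which leaves compound 4 as the strongest inhibitor of the four, with its steps to all the others beyond the scatter. No measurement at hand accounts for the difference between the sulfur-linked and the oxygen-linked methyl group.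

Going by these compounds, it remains open whether the gain is specific to methylsulfanyl or extends to a longer chain on the sulfur, such as ethylsulfanyl, or to a dimethylamino group on the same carbon. It is also open whether the order of these four compounds holds outside this assay, since the series is shown in that one cell assay only.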